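This account rests on a few compounds, and the source may have more. Where it says the series, first, only, none or still open, it means among the compounds named here.

Measured so far in a functional assay on COLO 205 cells (Homo sapiens) for antiproliferative activity; a higher number here means a weaker inhibitor of growth, a lower number a stronger inhibitor of growth:
Compound 1, `COCCCCCCCCCCCCCCC/C=C1\CC(CO)(COC(=O)C(C)(C)C)OC1=O`, gives 0.118 ug/mL.
Compound 2, `CCCCCOCCCCCCC/C=C1\CC(CO)(COC(=O)C(C)(C)C)OC1=O`, gives 0.491 ug/mL.
Compound 3, `COCCCCCCCCCCC/C=C1\CC(CO)(COC(=O)C(C)(C)C)OC1=O`, gives 0.541 ug/mL.

Compound 3 carries the highest number of the three. Its gap to compound 2 lies within the scatter, while the step of a 4.6-fold higher number from compound 1 to compound 3 (0.66 log units; beyond the scatter) lies beyond it. Compound 4, `CC(=O)OCCCCCCCCCCCCCCC/C=C1\CC(CO)(COC(=O)C(C)(C)C)OC1=O`, is the next case. 4-acetoxybutyl in place of methoxy on a saturated chain carbon, ten or more bonds along the chain from a double-bonded chain carbon The step that bears on it is a 4.6-fold higher number from compound 1 to compound 3 (0.66 log units; beyond the scatter), which runs the other way: compound 1, with the longer methoxy-terminated chain, sits well below compound 3. Going by the values given here, no measured pair shows an acetoxy end. The chain lengthening alone suggests a modest fall in this assay, tempered by the untested ester end. Compound 4 is therefore expected to give 0.18 ug/mL, between 0.07 ug/mL and 0.45 ug/mL, a step of a 3.0-fold lower number from compound 3 to compound 4 (0.48 log units; beyond the scatter).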

Compound 4, concentration for 50% growth inhibition: 2.1 ug/mL
Estimate against measurement, compound 4: 12-fold (1.07 log units) below, outside the stated range (above it).
By their numbers in this assay, from the lowest: compound 1; then compounds 2 and 3 (each within the scatter of the next); then compound 4.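

In this assay, acetyl in place of methyl on an oxygen on a saturated carbon gives an 18-fold higher number from compound 1 to compound 4 (1.25 log units; beyond the scatter), so at this far chain position the end group matters as well as the chain length. The long chain alone does not secure a low number: the acetoxy-ended chain gives a 3.9-fold higher number from compound 3 to compound 4 (0.59 log units; beyond the scatter) and a 4.3-fold higher number from compound 2 to compound 4 (0.63 log units; beyond the scatter), against the earlier link between a longer chain and a lower number. Nothing available explains this change. From the compounds shown here alone, whether a hydroxyl, an amine or a carboxylic acid at the chain end would track the methoxy or the acetoxy end remains open, as does the effect of an acetoxy end on a shorter chain.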